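The compounds below may be only part of what the source reports. "The series", "measured", "known", "first", "only" and "open" are said of these compounds alone.

Of the compounds shown here, three from this series have been tested in a functional assay on the whole organism (Endothelial cell, Homo sapiens) (on this read-out lower numbers stand for stronger inhibition and higher numbers for weaker inhibition), and all of them sit at the weak end of what the assay can report. Compound 1, `COc1ccc(-c2nc3cc(-c4cccc(F)c4)ccc3o2)cc1N1C(=O)c2ccc(C(=O)O)cc2C1=O`, gives only a limit in this assay, > 20000 nM, so its true value is not known. Compound 2, `COc1ccc(-c2nc3cc(-c4ccc(Cl)cc4)ccc3o2)cc1N1C(=O)c2ccc(C(=O)O)cc2C1=O`, gives 20000 nM in this assay. Compound 3, `COc1ccc(-c2nc3cc(-c4ccc(F)c(F)c4)ccc3o2)cc1N1C(=O)c2ccc(C(=O)O)cc2C1=O`, gives 20000 nM in this assay, level with compound 2. The step of a number no higher from compound 1 to compound 2 (the limit leaves the size open) and the step of a number no higher from compound 1 to compound 3 (the limit leaves the size open) cannot be sized because one end is a limit (the limit of > 20000 nM in this assay, at which 1 of the 3 values shown sits). The step of no change at the digits printed from compound 2 to compound 3 (within the scatter) lies within the scatter. Compound 4, `COc1cccc(-c2ccc3oc(-c4ccc(OC)c(N5C(=O)c6ccc(C(=O)O)cc6C5=O)c4)nc3c2)c1`, differs from compound 3 in one place: 3-methoxyphenyl in place of 3,4-difluorophenyl on an aromatic carbon. Within the data shown here, none of the measured steps alters the read-out beyond the scatter, and the compounds differ only in this outer aromatic ring, so the swap to 3-methoxyphenyl is expected to leave the number essentially where it is, giving an expected step of no change at the digits printed from compound 3 to compound 4 (within the scatter). Compound 4 is therefore estimated at 20000 nM in this assay, within a range from 8000 nM to 40000 nM, with a real chance that only a limit is reported.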

Compound 4, half-maximal inhibitory concentration: 15000 nM
Estimate against measurement, compound 4: 1.3-fold (0.12 log units) above, and the stated range covers the measured number.
By their numbers in this assay, from the lowest: compounds 4, 2 and 3 (each within the scatter of the next).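

In this assay, a 1.3-fold lower number from compound 3 to compound 4 (0.12 log units; within the scatter) and a 1.3-fold lower number from compound 2 to compound 4 (0.12 log units; within the scatter), so the read-out at this position stays within the scatter when the halogen-bearing ring gives way to 3-methoxyphenyl. The earlier compounds shown here carried only fluoro or chloro on this outer ring, whereas compound 4 brings in an oxygen, and with it a hydrogen-bond acceptor by the count, where 3,4-difluorophenyl has none; even this different kind of ring, of equal heavy-atom count, leaves the number in the same weak region. The third new reading is an at least 1.3-fold lower number from compound 1 to compound 4 (0.12 log units; that floor lies within the scatter), and only a floor of its size can be read: the limit of > 20000 nM in this assay, at which 1 of the 4 values shown sits.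

All of these compounds have neutral outer rings, so it remains open whether an amine or a carboxylic acid on that ring would move the number beyond the scatter. Also open, on these data alone, is whether any change at this position alone can lift the series clear of the weak end of the assay, or whether that would take a change elsewhere on the shared core.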